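Chloro to hydrogen on the pendant phenyl ring

A few compounds are considered here, and "the series" means these few. Any claim that something is new, unique, unknown or untested is made for them only; others in the source may bear on it.

Three compounds carry the shared core and differ in the ether-linked aryl part. Compound 1 `Cn1c(=O)[nH]c2ccc(OCCc3cccc(Cl)c3)cc21`, compound 2 `Cn1c(=O)[nH]c2ccc(OCc3ccc(Cl)cc3)cc21` and compound 3 `Cn1c(=O)[nH]c2ccc(OCc3ccc(Cl)c(Cl)c3)cc21` were all tested in an assay on cells for inhibition of Amine oxidase [flavin-containing] B (Homo sapiens), read by fluorescence, with stated times of 30 min and 15 min, tested at 1 uM; on this read-out lower numbers stand for less inhibition and higher numbers for more inhibition at the one concentration tested (going by the name of the read-out). Compound 3 gives 32.4%, compound 1 gives 13.7%, and compound 2 gives 8.29%. The difference between the cores of compound 1 and compound 3 is not broken down here.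

Compound 3 and compound 2 differ in one place, (hydrogen in place of chloro on an aromatic carbon), and this change is worth a number 24.1 percentage points lower from compound 3 to compound 2 (beyond the scatter). Compound 4 `Cn1c(=O)[nH]c2ccc(OCCc3ccccc3)cc21` has not yet been measured in this assay. It stands to compound 1 as compound 2 stands to compound 3: hydrogen in place of chloro on an aromatic carbon. It is the same kind of change, not the same: in the pair of compound 3 and compound 2 the carbon that loses its chloro is ortho to a chloro group and meta to a large group, while in the pair of compound 1 and compound 4 it is meta to a large group only, with no second chloro present.

Because compound 1 already sits at 13.7%, near compound 2 at 8.29%, the room for a drop is small, and the expected step is a number 6.7 percentage points lower from compound 1 to compound 4 (within the scatter). For compound 4 the estimate in this assay is 7%, with a range expected between 0% and 16%.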

Compound 4, a percentage reported as inhibition, at one concentration (the size of the read-out at that concentration, not a potency): "not active" (no number reported)
Compound 4: no number reported; no gap can be computed for the estimate.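

In this assay, among the compounds shown here, compound 4 is reported as not active, with no number, and no step from compound 1 to compound 4 can be read. Nothing shown here bears on this result. Going by these compounds, the actual size of the 3-chlorophenyl to phenyl change between compound 1 and compound 4 stays open. The compounds shown leave open how that change compares with a number 24.1 percentage points lower from compound 3 to compound 2 (beyond the scatter).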